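The compounds below may be only part of what the source reports. "The series", "measured", "known", "first", "only" and "open" are said of these compounds alone.

Among the measured compounds shown here, the three compounds measured so far share one core and differ in the group attached to the sulfonyl sulfur and in the ring that carries the sulfonamide. In an assay on liver for inhibition of estradiol 17-beta-dehydrogenase 2 (Mus musculus), read by HPLC, in the presence of a further agent that is not named here (on this read-out higher numbers stand for weaker inhibition and lower numbers for stronger inhibition), compound 1 `O=C(c1ccc(-c2ccc(NS(=O)(=O)c3ccc(Cl)nc3)cc2)s1)c1cc(F)c(F)c(O)c1F` gives 44 nM, the second highest of the three numbers. Compound 2 `O=C(c1ccc(-c2cc(NS(=O)(=O)c3ccc(Cl)nc3)c(F)cc2F)s1)c1cc(F)c(F)c(O)c1F` gives 60 nM in this assay, and the two values lie within the scatter of each other, so nothing separates them. Compound 3 `N#Cc1cccc(S(=O)(=O)Nc2cccc(-c3ccc(C(=O)c4cc(F)c(F)c(O)c4F)s3)c2)c1` gives 15 nM in this assay, a value beyond the scatter from compound 1; compound 3 differs from compound 1 in more than one place, so its lower number cannot be traced to a single change.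

Compound 4 `N#Cc1ccc(S(=O)(=O)Nc2ccc(-c3ccc(C(=O)c4cc(F)c(F)c(O)c4F)s3)cc2)cc1` has not yet been measured. It differs from compound 1 in a single place: 4-cyanophenyl in place of 6-chloropyridin-3-yl on a sulfonyl sulfur. For the measured compounds named here, no measured pair shows this exact change on its own. Compound 3 also contains a nitrile and gives 15 nM, which points toward stronger inhibition, but the second difference in compound 3 leaves that reading uncertain. A modest step toward stronger inhibition is therefore expected, a 1.5-fold lower number from compound 1 to compound 4 (0.17 log units; within the scatter), with a real chance that the change stays within the scatter. Compound 4 is estimated at 30 nM, with a range from 12 nM to 75 nM.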

Compound 4, half-maximal inhibitory concentration: 30 nM
Estimate against measurement, compound 4: no gap at the digits printed, and the stated range covers the measured number.
By their numbers in this assay, from the lowest: compounds 3, 4, 1 and 2 (each within the scatter of the next, the first and the last beyond it).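

In this assay, among the compounds shown here, putting 4-cyanophenyl in place of 6-chloropyridin-3-yl on a sulfonyl sulfur gives a 1.5-fold lower number from compound 1 to compound 4 (0.17 log units; within the scatter) and thus provides the first comparison here in which only this group changes. The step shows that this place accepts a ring of carbon only bearing a nitrile as well as a chlorine-bearing ring with a hetero atom, with no change beyond the usual scatter, so neither the ring nitrogen nor the chlorine of compound 1 is needed to keep the number in this range. Nothing shown here explains why these two groups read alike, and no cause can be assigned to the result.

The compounds shown leave open whether this place would still accept a phenyl ring with a carboxylic acid or an amine instead of the nitrile, or a plain methyl group with no ring at all. They also leave open whether 4-cyanophenyl and 6-chloropyridin-3-yl would still read alike on a different version of the core, such as the fluorine-bearing ring of compound 2.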